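Shortening a Phenyl-Tipped Chain on a Lactone Amide

The compounds below may be only part of what the source reports. "The series", "measured", "known", "first", "only" and "open" are said of these compounds alone.

Of the compounds shown here, three have been measured in a functional assay on PC-3 cells (Homo sapiens) for cytotoxicity, read by sulforhodamine B assay, with a stated time of 5 days; a lower number here means a stronger inhibitor, a higher number a weaker inhibitor. Compound 1 `O=C(CCCCCCCc1ccccc1)N[C@H]1CCOC1=O` gives 85000 nM. Compound 2 `O=C(CCCCCCCCCCCc1ccccc1)CC(=O)N[C@H]1CCOC1=O` gives 4000 nM, and compound 3 `O=C(CCCCCCCCCCc1ccccc1)CC(=O)N[C@H]1CCOC1=O` gives 2000 nM. The difference between the cores of compound 1 and compound 2 is not broken down here; what the values show is that compound 1 has the highest number of the three, beyond the scatter from both others.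

Compound 3 differs from compound 2 by phenyl in place of benzyl on a saturated chain carbon, ten or more bonds along the chain from a carbonyl carbon. That change gave a 2.0-fold lower number from compound 2 to compound 3 (0.30 log units; within the scatter).

The unmeasured compound 4 `O=C(CCCCCCc1ccccc1)N[C@H]1CCOC1=O` differs from compound 1 by phenyl in place of benzyl on a saturated chain carbon, six bonds along the chain from a carbonyl carbon. This is the same kind of change, yet the place along the chain is not the same, as the two differences show, and the cores differ as well.

In this assay the step from compound 1 to compound 4 is expected to be a 1.1-fold lower number from compound 1 to compound 4 (0.03 log units; within the scatter), no larger than the earlier one, because that earlier step a 2.0-fold lower number from compound 2 to compound 3 (0.30 log units; within the scatter) stayed within the scatter. Compound 4 is therefore estimated to give 80000 nM, expected to fall between 30000 nM and 250000 nM.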

Compound 4, half-maximal inhibitory concentration: > 100000 nM
Compound 4 ended at the assay's limit; the forecaster's own chance of this, stated with the estimate: 15%; at least 1.2-fold (0.09 log units) between middle value and limit.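

In this assay compound 4 gives > 100000 nM, which is a limit of the assay and not an exact number. Phenyl in place of benzyl, on a saturated chain carbon six bonds along the chain from a carbonyl carbon, therefore comes out as an at least 1.1-fold higher number from compound 1 to compound 4 (0.07 log units; that floor lies within the scatter), and this figure is only a floor for the true size of the step. The result neither shows that the change acts the same way on both cores nor shows that it acts differently: the same change on two cores in this assay, a 2.0-fold lower number (0.30 log units; within the scatter) from compound 2 to compound 3 and an at least 1.1-fold higher number (0.07 log units; that floor lies within the scatter) from compound 1 to compound 4; the limit leaves it open whether they differ.

The compounds shown leave open how the number would respond to a longer chain on the core of compound 1, where a step could be read in full if the value stayed inside the range of the assay. From the compounds shown here alone, it also remains open whether an amine or a carboxylic acid in place of the phenyl at the chain end would change the number on the core of compound 3.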